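The source may hold more compounds than are shown below. What is called first, only, known or untested is meant among the compounds shown, and "the series" means these compounds.

Of the compounds shown here, three have so far been measured in a functional assay on CHO cells for agonist activity at Free fatty acid receptor 1 (Homo sapiens); on this read-out lower numbers stand for an effect already at smaller amounts and higher numbers for an effect only at larger amounts of compound. Compound 1, with the structure `Cc1nc(-c2ccc(C(F)(F)F)cc2)sc1CNc1ccc(C(=O)O)cc1`, gives in this assay only a limit, < 10000 nM, and not a number. Compound 2, with the structure `Cc1nc(-c2ccc(C(F)(F)F)cc2)sc1CNc1ccc(/C=C/C(=O)O)cc1`, gives 36.3 nM in this assay. Within the data shown here, the one step between neighbouring structures, a step that the limit leaves unreadable from compound 1 to compound 2, cannot be sized, because the limit of < 10000 nM in this assay, at which 1 of the 3 values shown sits, hides where compound 1 truly stands. Compound 3, with the structure `O=C(O)COc1ccc(NCc2cccc(Oc3ccccc3)c2)cc1`, gives 2040 nM in this assay, the higher of the two readable numbers; compound 2 sits far toward lower numbers, well beyond the usual scatter. The value of compound 1 is a limit and allows no comparison.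

Compound 4, with the structure `NC(=O)CCc1ccc(NCc2cccc(Oc3ccccc3)c2)cc1`, has not yet been measured. It differs from compound 3 in one place: 2-carbamoylethyl in place of carboxymethoxy on an aromatic carbon. Among the measured compounds shown here, no measured step bears on this kind of change, since the only step available concerns a different group and is itself unreadable. The expectation must therefore rest on compound 3 alone, with wide uncertainty. Compound 4 is expected to give about 6000 nM in this assay, with a likely range from 1500 nM to 30000 nM. The step from compound 3 to compound 4 is thus estimated as a 2.9-fold higher number from compound 3 to compound 4 (0.47 log units; beyond the scatter), with a real chance that only a limit is reported.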

Compound 4, half-maximal effective concentration: 51.3 nM
Estimate against measurement, compound 4: 120-fold (2.07 log units) above; the whole stated range lies above it.
By their numbers in this assay, from the lowest: compounds 2 and 4 (each within the scatter of the next); then compound 3.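

In this assay, putting 2-carbamoylethyl in place of carboxymethoxy, on an aromatic carbon para to a large group, gives a 40-fold lower number from compound 3 to compound 4 (1.60 log units; beyond the scatter), so this position responds strongly to what stands on it, even though both groups count 5 heavy atoms. Compounds 1 to 3 all end in a carboxylic acid, and compound 4, which ends in an amide, shows that on this core a carboxylic acid at this place is not needed for a low number. Nothing among the data shown accounts for the size of this step.

The change alters two things at once, the ether oxygen on the ring and the end of the chain, and the compounds shown cannot tell which of them matters; a 2-carboxyethyl group or a carbamoylmethoxy group at this place would pull the two apart. Also open, from the compounds shown here alone, is how much depends on the amide itself, which a nitrile, an amine or a longer chain ending in the same amide could test.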